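The compounds below may be only part of what the source reports. "The series", "measured", "known", "first", "only" and "open" are said of these compounds alone.

Measured so far:
compound 1 `COc1ccc(-c2cc(/C=C/C(=O)c3ccc(N)cc3)[nH]n2)cc1`: 1250 nM
compound 2 `COc1cc(-c2cc(/C=C/C(=O)c3ccc(Cl)c(Cl)c3)[nH]n2)cc(OC)c1OC`: 6990 nM

In a functional assay on OVCAR-3 cells (Homo sapiens) for inhibition, read by sulforhodamine B assay, with a stated time of 48 h (a lower number here means a stronger inhibitor of growth, a higher number a weaker inhibitor of growth), compound 2 gives the higher of the two numbers; compound 1 sits lower, and that gap lies beyond the scatter. The two differ in more than one place, so no single step can be read from them.

Compound 3 `COc1cc(-c2cc(/C=C/C(=O)c3ccc(F)c(F)c3)[nH]n2)cc(OC)c1OC` carries 3,4-difluorophenyl in place of 3,4-dichlorophenyl on a carbonyl carbon. For the measured compounds named here, no measured pair shows this change. The expected step of a 1.3-fold higher number from compound 2 to compound 3 (0.11 log units; within the scatter) is small, with no clear direction beyond the scatter. Compound 3 is therefore estimated at 9000 nM, in the range 3500 nM to 25000 nM.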

Compound 3, concentration for 50% growth inhibition: 2390 nM
For compound 3 the middle estimate is 3.8-fold (0.58 log units) above the measured one; measured number outside the range, below it.
By their numbers in this assay, from the lowest: compounds 1 and 3 (each within the scatter of the next); then compound 2.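

In this assay, 3,4-difluorophenyl in place of 3,4-dichlorophenyl on a carbonyl carbon gives a 2.9-fold lower number from compound 2 to compound 3 (0.47 log units; beyond the scatter). For the compounds shown here, this is the first single-place comparison: with the rest of the structure held constant, the identity of the two halogens on this ring alone moves the number beyond the scatter. Nothing measured here accounts for the step.

Still open, as far as these compounds go, is how a nitrile or a carboxylic acid would read on this ring. Also open, from the compounds shown here alone, is whether the same change carries over to the core of compound 1.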